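A few compounds are considered here, and "the series" means these few. Any claim that something is new, unique, unknown or untested is made for them only; others in the source may bear on it.

Three compounds have so far been measured in a functional assay on RXF 393 cells (Homo sapiens) for cytotoxicity, read by sulforhodamine B assay, with a stated time of 48 h, tested at 0.001 uM; a lower number here means a stronger effect, a higher number a weaker effect of the compound at the concentration tested:

- Compound 1, `COc1cc(C)cc(-c2c(-c3ccnc(-c4ccc(C(C)=O)cc4)c3)cnn2CC#N)c1`, gives 86%.
- Compound 2, `COc1cc(C)cc(-c2nn(CC#N)cc2-c2ccc(-c3cccc(C(C)=O)c3)nc2)c1`, gives 90%.
- Compound 3, `Cc1cc(O)cc(-c2nn(CC#N)cc2-c2ccnc(-c3ccc(Oc4ccccc4)cc3)c2)c1`, gives 88%.

All three numbers sit close together. The number of compound 3 differs from that of compound 1 and from that of compound 2 by amounts that lie within the usual scatter of repeated measurements, so the three compounds cannot be told apart on this read-out; each of them leaves most of the cells unaffected at the concentration tested.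

Compound 4, `Cc1cc(O)cc(-c2nn(CC#N)cc2-c2ccnc(-c3ccc(N(C)C)cc3)c2)c1`, has not yet been measured. It shares the core of compound 3 and differs in one place: dimethylamino in place of phenoxy on an aromatic carbon. Within the data shown here, nothing among the measured compounds shows what such a swap does in this assay, since no two of them differ from each other in one place only.

Among the measured compounds shown here, with the three known numbers all close to one another, the expected step of no change at the digits printed from compound 3 to compound 4 (within the scatter) is none beyond the scatter. Compound 4 is therefore estimated to give 88%, with a likely range from 78% to 98%, in line with the number of compound 3.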

Compound 4, a percentage reported as activity, at one concentration (the size of the read-out at that concentration, not a potency): 100%
The estimate for compound 4 lay 12 percentage points below the measured number, outside the stated range (above it).
By their numbers in this assay, from the lowest: compounds 1, 3, 2 and 4 (each within the scatter of the next, the first and the last beyond it).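

In this assay, the swap of phenoxy for dimethylamino on an aromatic carbon, para to a large group, gives a number 12 percentage points higher from compound 3 to compound 4 (beyond the scatter), so this position can change the read-out and this change weakens the effect at the concentration tested. Among these compounds, this is the first single change seen, and it shows that the group at this place is not interchangeable, even though the earlier numbers gave no hint of that. The swap replaces 7 heavy atoms and a six-membered aromatic ring with 3 heavy atoms and no ring, while the counts of hydrogen-bond donors and acceptors stay the same, but nothing measured explains why the number moves.

One pair cannot separate the loss of the ring from the change of the linking atom: methoxy would keep the oxygen without the ring, and phenylamino would keep the ring with a nitrogen as the link. Also open, as far as these compounds go, is whether the same swap would have a similar effect on the core of compound 1, which carries an acetyl-bearing ring in this region instead.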